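Aminothiophene piperazines: aryl swap toward compound 4

The source may report more compounds than this note shows. Statements on the series, on what has been measured and on what is new or still open speak of the compounds shown alone.

Three measured compounds share one core and differ only in the aryl group on the ring amine nitrogen. In a functional assay on CHO cells with adenosine receptor A1 (Homo sapiens) as the target, read by cAMP accumulation and immunoassay, with a stated time of 6 min, tested at 0.1 uM (a lower number here means a stronger effect, a higher number a weaker effect of the compound at the concentration tested), compound 1 `Nc1scc(CN2CCN(c3ccc([N+](=O)[O-])cc3)CC2)c1C(=O)c1ccc(Cl)cc1` gives -13%, compound 2 `Nc1scc(CN2CCN(c3cccc(C(F)(F)F)c3)CC2)c1C(=O)c1ccc(Cl)cc1` gives -30% and compound 3 `Nc1scc(CN2CCN(c3ccc(OC(F)(F)F)cc3)CC2)c1C(=O)c1ccc(Cl)cc1` gives -13%. Compound 3 thus stands level with compound 1, together the highest of the three numbers, with compound 2 the furthest, shown by a number 17 percentage points higher from compound 2 to compound 3 (beyond the scatter). Compound 4 `Nc1scc(CN2CCN(c3ccccc3F)CC2)c1C(=O)c1ccc(Cl)cc1` carries 2-fluorophenyl in place of 4-(trifluoromethoxy)phenyl on an amine nitrogen in a ring. Going by the values given here, no measured step covers this exact exchange; the nearest guides are a number 17 percentage points lower from compound 1 to compound 2 (beyond the scatter) and no change at the digits printed from compound 1 to compound 3 (within the scatter), which show aryl changes move the read-out at most modestly. Compound 4 is therefore expected to land near the measured range, with a number 5 percentage points lower from compound 3 to compound 4 (within the scatter) as the estimated step. The estimate for compound 4 is -18%, between -35% and 0%.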

Compound 4, a percentage reported as activity, at one concentration (the size of the read-out at that concentration, not a potency): -1%
For compound 4 the middle estimate is 17 percentage points below the measured one; the measured number falls inside the stated range.
By their numbers in this assay, from the lowest: compound 2; then compounds 1 and 3 (each within the scatter of the next); then compound 4.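

In this assay, a number 12 percentage points higher from compound 3 to compound 4 (beyond the scatter) and a number 12 percentage points higher from compound 1 to compound 4 (beyond the scatter) and a number 29 percentage points higher from compound 2 to compound 4 (beyond the scatter) put 2-fluorophenyl at the weakest effect of the four on this amine nitrogen. Going by these compounds alone, all three steps lie beyond the scatter, so the aryl exchange reaches further in this direction than the earlier compounds showed. No evidence on the cause of this shift is at hand.

The compounds shown do not separate the fluorine from its place on the aryl ring. From the compounds shown here alone, how a carboxylic acid or a longer chain on this nitrogen would read stays open.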